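This account rests on a few compounds, and the source may have more. Where it says the series, first, only, none or still open, it means among the compounds named here.

Compound 1 `CC(=O)c1ccc(NC(=O)CSc2nc3c(c(=O)n2-c2ccccc2)SCC3)cc1` and compound 2 `CCOC(=O)c1ccc(NC(=O)CSc2nc3c(c(=O)n2-c2ccccc2)SCC3)cc1` share one core and differ only in the group on the carbonyl carbon. In an assay on L cells for inhibition of Protein-serine O-palmitoleoyltransferase porcupine (Mus musculus), read by reporter gene assay, with a stated time of 24 h (a higher number here means that more compound is needed for the effect, a lower number that less compound is needed), compound 1 gives a limit of the assay, > 1000 nM, as the limit of > 1000 nM in this assay, at which 1 of the 2 values shown sits, records. In this assay, for the measured compounds named here, compound 2 gives 300 nM, the only true number measured so far, and the change from compound 1 to compound 2 is an at least 3.3-fold lower number from compound 1 to compound 2 (0.52 log units; beyond the scatter). Compound 3 `O=C(CSc1nc2c(c(=O)n1-c1ccccc1)SCC2)Nc1ccc(N2CCCCC2)cc1`, not yet measured, differs from compound 2 by piperidin-1-yl in place of ethoxycarbonyl on an aromatic carbon. Going by the values given here, the one measured step altered the group on this same aromatic carbon and was at least modest, yet no measured step removes the carbonyl group entirely, so the size and direction of the change in this assay remain open. The expected step in this assay is a 1.7-fold higher number from compound 2 to compound 3 (0.22 log units; within the scatter), within the scatter. Compound 3 is estimated at 500 nM, in a range from 100 nM to 3000 nM.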

Compound 3, half-maximal effective concentration: 30 nM
Compound 3: the middle estimate sits 17-fold (1.22 log units) above what was measured; measured number outside the range, below it.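

This position does not depend on a carbonyl group: in this assay, putting piperidin-1-yl on the aromatic carbon in place of ethoxycarbonyl gives a 10-fold lower number from compound 2 to compound 3 (1.00 log units; beyond the scatter). Set against the acetyl group, the same replacement gives an at least 33-fold lower number from compound 1 to compound 3 (1.52 log units; beyond the scatter), so the group on this one carbon alone moves the number well beyond the scatter among the compounds shown. Compound 1 gives a limit and not a true number, so this second step can be read only as a minimum: the limit of > 1000 nM in this assay, at which 1 of the 3 values shown sits.

Going by these compounds, it remains open whether the ring or its nitrogen accounts for the step, and what an open-chain amine such as diethylamino, a cyclohexyl ring or a morpholine ring would give on this carbon. On these data alone, it is also open whether the effect of piperidin-1-yl would hold with a different group in place of the phenyl on the shared core.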